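Moving the chlorine from compound 3 to compound 4

The compounds below may be only part of what the source reports. "The series", "measured", "known", "first", "only" and "open" are said of these compounds alone.

Values in a functional assay on SW 1116 cells (Homo sapiens) for antiproliferative activity, read by MTT assay, with a stated time of 48 h; a lower number here means a stronger inhibitor, a higher number a weaker inhibitor:
- compound 1 `Brc1ccc(CSc2nnc(-c3cnccn3)o2)cc1`: 14400 nM
- compound 2 `Clc1ccccc1CSc1nnc(-c2cnccn2)n1-c1ccccc1`: 18100 nM
- compound 3 `Clc1cccc(CSc2nnc(-c3cnccn3)n2-c2ccccc2)c1`: 6610 nM

Compound 3 has the lowest number of the three, which makes it the strongest inhibitor so far. Compound 4 `Clc1ccc(CSc2nnc(-c3cnccn3)n2-c2ccccc2)cc1` carries 4-chlorobenzyl instead of 3-chlorobenzyl: 4-chlorophenyl in place of 3-chlorophenyl on a saturated chain carbon bound to a sulfur. Going by the values given here, the one closely related measured change is a 2.7-fold lower number from compound 2 to compound 3 (0.44 log units; beyond the scatter), where 3-chlorophenyl replaced 2-chlorophenyl at the same place. Compound 1 differs in more than one place and offers no clean comparison. A step no larger than that one is expected, with a slight lean towards a higher number. The estimated change is a 1.4-fold higher number from compound 3 to compound 4 (0.13 log units; within the scatter). For compound 4 the expected value is 9000 nM, with an estimated range from 3500 nM to 20000 nM.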

Compound 4, half-maximal inhibitory concentration: 12500 nM
Compound 4: the middle estimate sits 1.4-fold (0.14 log units) below what was measured, within the range that was stated.
By their numbers in this assay, from the lowest: compounds 3, 4, 1 and 2 (each within the scatter of the next, the first and the last beyond it).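

In this assay, the two new comparisons, a 1.9-fold higher number from compound 3 to compound 4 (0.28 log units; within the scatter) and a 1.4-fold lower number from compound 2 to compound 4 (0.16 log units; within the scatter), both stay within ordinary repeat variation, so 4-chlorophenyl cannot be told apart from either of the other two chlorine placements. Only a 2.7-fold lower number from compound 2 to compound 3 (0.44 log units; beyond the scatter) stands clear of the scatter, so among these three compounds, moving the chlorine around this ring has only a modest effect. Nothing measured here offers a reason for these numbers.

Still open, from the compounds shown here alone, is whether a phenyl without chlorine, or a methoxy group or an amine in place of the chlorine, would give a number outside this narrow spread.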